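A Sulfonyl Group Replaces a Carbamate Side Chain

The source may report more compounds than this note shows. Statements on the series, on what has been measured and on what is new or still open speak of the compounds shown alone.

Of the compounds shown here, three that share one core have been tested in an ADME assay on microsomes from liver (Mus musculus) for metabolic stability, read by LC-MS, with NADPH named in the record, with a stated time of 60 min, tested at 1 uM, in the absence of a further agent (on this read-out higher numbers stand for a more stable compound and lower numbers for a less stable compound), so far. Compound 1 (`COc1ccc(-c2c(C)nc3c(N4CC[C@@H](NC(=O)c5ccccc5)C4)cc(C)nn23)cc1OC`) gives > 95% as a limit of the assay and not a number. Compound 2 (`COc1ccc(-c2c(C)nc3c(N4CC[C@@H](NC(=O)NC(C)C)C4)cc(C)nn23)cc1OC`) gives > 95% as a limit too. Compound 3 (`COc1ccc(-c2c(C)nc3c(N4CC[C@@H](NC(=O)OC5CCCCC5)C4)cc(C)nn23)cc1OC`) gives > 95% as a limit as well. Compound 3 therefore has no exact place in the series, and the two other results are also limits.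

Compound 4 (`COc1ccc(-c2c(C)nc3c(N4CC[C@@H](NS(=O)(=O)c5ccc(C)cc5)C4)cc(C)nn23)cc1OC`) differs from compound 3 in one place, with (4-methylphenyl)sulfonyl in place of cyclohexyloxycarbonyl on an amine nitrogen. The measured steps that bear on this change are a step that the two limits leave unreadable from compound 1 to compound 2 and a step that the two limits leave unreadable from compound 1 to compound 3 and a step that the two limits leave unreadable from compound 2 to compound 3 and none of them has a readable size. None of them swaps a carbonyl group for a sulfonyl group.

Because of the limit of > 95% in this assay, at which 3 of the 3 values shown sit, for compound 1 and compound 2 and compound 3 no step beyond the usual scatter is expected in this assay and no direction can be named. The estimated a number no higher from compound 3 to compound 4 (the limit leaves the size open) is therefore expected to stay within that scatter. Compound 4 is estimated at 95% with an expected range from 82% to 100% in this measurement.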

Compound 4, percent of the compound remaining: > 95%
Compound 4: only a limit was reported; the forecaster's own chance of this, stated with the estimate: 55%; the middle value lies on the limit itself.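

The steps among compound 1, compound 2, compound 3 and compound 4 cannot be read, because each result is a limit of the assay and not a number: the limit of > 95% in this assay, at which 4 of the 4 values shown sit.

As far as these compounds go, how far these four compounds really differ in this assay stays open, including whether (4-methylphenyl)sulfonyl and cyclohexyloxycarbonyl on the amine nitrogen differ at all.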